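Trading Trifluoromethyl for Chloro on the Sulfonamide Aryl Ring

The source may report more compounds than this note shows. Statements on the series, on what has been measured and on what is new or still open speak of the compounds shown alone.

Measured so far:
compound 1 `CCc1ccccc1N(Cc1nnc(Cc2ccc(OC)cc2)o1)S(=O)(=O)c1ccc(C)cc1` 631 nM
compound 2 `CCOc1ccc(Cc2nnc(CN(c3ccccc3CC)S(=O)(=O)c3ccc(C)cc3)o2)cc1` 39.8 nM
compound 3 `COc1ccc(Cc2nnc(CN(c3cccc(C(F)(F)F)c3C)S(=O)(=O)c3ccc(C)cc3)o2)cc1` 398 nM

In a functional assay on CHO cells for antagonist activity at prostaglandin E2 receptor EP1 subtype (Homo sapiens), read by FLIPR and calcium flux (a higher number here means a weaker inhibitor, a lower number a stronger inhibitor), compound 3 gives 398 nM, the second highest of the three numbers; its nearest neighbour is compound 1, with a 1.6-fold lower number from compound 1 to compound 3 (0.20 log units; within the scatter), while compound 2 lies furthest away, with a 16-fold lower number from compound 1 to compound 2 (1.20 log units; beyond the scatter) separating it from compound 1. Compound 4 `COc1ccc(Cc2nnc(CN(c3cccc(Cl)c3C)S(=O)(=O)c3ccc(C)cc3)o2)cc1` has not yet been measured. It differs from compound 3 in one place: chloro in place of trifluoromethyl on an aromatic carbon.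

Among the compounds with values here, of the two measured steps, only the one from compound 1 to compound 3 touches the same aryl ring on the sulfonamide nitrogen, and that step, a 1.6-fold lower number from compound 1 to compound 3 (0.20 log units; within the scatter), stayed within the scatter even though it changed the ring more broadly than the present swap does. The step from compound 1 to compound 2 sits on the other end of the molecule and says nothing about this change. Within the data shown here, with no step on record that isolates the trifluoromethyl-to-chloro exchange, the expectation for compound 4 is a number close to that of compound 3 in this assay, without a direction beyond the scatter, so the estimated step is a 1.0-fold higher number from compound 3 to compound 4 (0.00 log units; within the scatter). Compound 4 is therefore expected to give about 400 nM, in a range from 160 nM to 1000 nM.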

Compound 4, inhibition constant: 39.8 nM
Compound 4: the middle estimate sits 10-fold (1.00 log units) above what was measured; measured number outside the range, below it.
By their numbers in this assay, from the lowest: compounds 2 and 4 (each within the scatter of the next); then compounds 3 and 1 (each within the scatter of the next).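

In this assay, the aromatic carbon carrying the trifluoromethyl group of compound 3 proves responsive to what stands on it, as chloro in its place gives a 10-fold lower number from compound 3 to compound 4 (1.00 log units; beyond the scatter). The ring on the sulfonamide nitrogen had seemed indifferent when only 2-methyl-3-(trifluoromethyl)phenyl replaced 2-ethylphenyl, but 3-chloro-2-methylphenyl in the same place gives a 16-fold lower number from compound 1 to compound 4 (1.20 log units; beyond the scatter), so the earlier flat step depended on the group at this one carbon. No measurement shown here explains the difference between chloro and trifluoromethyl at this carbon.

On these data alone, whether a bromo group or a nitrile on this carbon would keep the lower number remains open. So does whether the ethoxy group of compound 2 and the chloro group of compound 4 would add up in a single molecule.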